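A few compounds are considered here, and "the series" means these few. Any claim that something is new, unique, unknown or untested is made for them only; others in the source may bear on it.

In a functional assay on DU-145 cells (Homo sapiens) for inhibition, read by MTT assay, with a stated time of 48 h (a higher number here means a weaker inhibitor, a lower number a stronger inhibitor), compound 1 `O=Cc1cccc(OCc2cn(Cc3ccccc3)nn2)c1` gives > 50000 nM, which is a limit of the assay rather than a number. Compound 2 `O=C1Nc2ccc(F)cc2/C1=C\c1cccc(OCc2cn(Cc3ccccc3)nn2)c1` stands with "not determined" (no result reported) in this assay. Compound 3 `O=C1Nc2ccc(C(c3ccccc3)c3ccccc3)cc2/C1=C\c1cccc(OCc2cn(Cc3ccccc3)nn2)c1` in this assay gives > 50000 nM, again a limit and not a number. So compound 3 stands at the limit of > 50000 nM in this assay, at which 2 of the 3 values shown sit, alongside compound 1, with no single figure among the three compounds shown. Compound 4 `O=C1Nc2ccc(C(c3ccccc3)c3ccccc3)cc2/C1=C/c1cccc(OCc2cn(Cc3ccccc3)nn2)c1` is the next step: the two compounds have the same atoms and bonds and differ only in configuration as drawn: 1 of 1 stereo elements differ; a double bond is drawn E in compound 3 and Z in compound 4. Among the compounds with values here, no comparable step between measured compounds is available, so the account rests on the limit of compound 3 alone. Compound 4 is expected to sit close to compound 3, with a step that the limit leaves unreadable from compound 3 to compound 4 that does not go beyond the scatter, so compound 4 is estimated at 60000 nM, with a range from 15000 nM to 200000 nM in this assay.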

Compound 4, half-maximal inhibitory concentration: 3700 nM
Compound 4: middle estimate off by 16-fold (1.21 log units), on the high side, and the stated range ends above it.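

Earlier compounds gave no number in this assay, and the double bond now proves decisive there, with an at least 13-fold lower number from compound 3 to compound 4 (1.13 log units; beyond the scatter), so the Z form of compound 4 yields a readable value. Compound 3 remains at > 50000 nM, which is a limit and not a number. The step can be put down to the double bond alone, because nothing else separates the pair: the fact that compounds 3 and 4 differ only in the configuration as drawn.

On these data alone, what stays open is whether this configuration gives a similar step when an amine or a carboxylic acid stands in place of the group carried on the shared core.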